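Carbonyl aryl swap: bromo to nitro, untested ground

The source may hold more compounds than are shown below. What is called first, only, known or untested is meant among the compounds shown, and "the series" means these compounds.

Compound 3 `O=C(/C=C/c1ccc(OCc2cn(Cc3cccc(F)c3)nn2)cc1)c1ccc(Br)cc1` gives 42% in a functional assay on MCF7 cells (Homo sapiens) for inhibition, read by MTT assay, with a stated time of 48 h, tested at 10 uM (on this read-out higher numbers stand for more inhibition of growth at the one concentration tested and lower numbers for less inhibition of growth), and stands second highest of the three measured numbers. Its nearest neighbour is compound 1 `O=C(/C=C/c1ccc(OCc2cn(Cc3ccccc3Br)nn2)cc1)c1ccc(Br)cc1`, which gives 44%; the step of a number 2 percentage points lower from compound 1 to compound 3 (within the scatter) is within the scatter, so no order can be read between the two. Furthest away is compound 2 `O=C(/C=C/c1ccc(OCc2cn(Cc3ccc(Br)cc3)nn2)cc1)c1ccc(Br)cc1`, which gives 23%; the step of a number 19 percentage points higher from compound 2 to compound 3 (beyond the scatter) is beyond the scatter, as is a number 21 percentage points lower from compound 1 to compound 2 (beyond the scatter).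

Compound 4 `O=C(/C=C/c1ccc(OCc2cn(Cc3cccc(F)c3)nn2)cc1)c1ccc([N+](=O)[O-])cc1` differs from compound 3 by nitro in place of bromo on an aromatic carbon. Every measured step in this set changes the aryl group on the saturated chain carbon bound to the aromatic nitrogen, at the far end of the molecule from the carbonyl; none touches the ring that carries the carbonyl. Within the data shown here, no measured step therefore bears on the change from compound 3 to compound 4, and the expectation rests on the position alone, with no numerical support.

On that basis compound 4 is expected to show a step of a number 2 percentage points lower from compound 3 to compound 4 (within the scatter) in this assay that does not go beyond the scatter in either direction. Compound 4 is estimated at 40%, within a wide range from 18% to 62%.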

Compound 4, percent growth inhibition at one concentration: 30%
Beside the measured number, compound 4's estimate is 10 percentage points above it; measured number inside the range.
By their numbers in this assay, from the lowest: compounds 2 and 4 (each within the scatter of the next); then compounds 3 and 1 (each within the scatter of the next).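

In this assay, among these compounds, nitro in place of bromo on an aromatic carbon, para to a large group, gives a number 12 percentage points lower from compound 3 to compound 4 (beyond the scatter) and so provides the first reading at the ring that carries the carbonyl. Among the compounds shown here, the series therefore responds to a change at this end of the molecule as well as to changes in the aryl group on the saturated chain carbon bound to the aromatic nitrogen, although this rests on a single pair, with 4-bromophenyl and 4-nitrophenyl as the only two groups compared here. No supporting measurement bears on the cause of this step.

As far as these compounds go, the nitro group appears here only with the 3-fluorophenyl group at the far end, so it remains open whether the change from bromo to nitro would read the same way with the 2-bromophenyl or 4-bromophenyl group in that place. Also open, from the compounds shown here alone, is how an amine, a carboxylic acid or a methoxy group on the same aromatic carbon would read, and whether any of these would stand on the bromo or the nitro side of this step.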